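Methoxy in Place of Bromo on Compound 3

A few compounds are considered here, and "the series" means these few. Any claim that something is new, unique, unknown or untested is made for them only; others in the source may bear on it.

Of the compounds shown here, three built on one shared core have been measured. Compound 1 `COC(=O)[C@@]1(C)CCC=C2[C@@H]1CC[C@@H](C)[C@]2(C)Cc1c[nH]c2ccccc12` gives 4200 nM in a functional assay on T47D cells (Homo sapiens) for inhibition, read by sulforhodamine B assay, with a stated time of 48 h; a lower number here means a stronger inhibitor of growth, a higher number a weaker inhibitor of growth. Compound 2 `COC(=O)[C@@]1(C)CC[C@@H]2C3=C1CC[C@@H](C)[C@]3(C)C[C@@H]1c3ccccc3N[C@H]21` gives 35000 nM in this assay, and compound 3 `COC(=O)[C@@]1(C)CC[C@@H]2C3=C1CC[C@@H](C)[C@]3(C)C[C@@H]1c3cc(Br)ccc3N[C@H]21` gives 31000 nM. Compound 3 thus stands second highest of the three numbers; its nearest neighbour is compound 2, and the step of a 1.1-fold lower number from compound 2 to compound 3 (0.05 log units; within the scatter) lies within the scatter, while compound 1 sits at a number beyond the scatter below compound 3.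

Compound 4 `COC(=O)[C@@]1(C)CC[C@@H]2C3=C1CC[C@@H](C)[C@]3(C)C[C@@H]1c3cc(OC)ccc3N[C@H]21` differs from compound 3 in one place: methoxy in place of bromo on an aromatic carbon. Within the data shown here, the only measured step touching that aromatic carbon, a 1.1-fold lower number from compound 2 to compound 3 (0.05 log units; within the scatter), put a bromo where a hydrogen had been and moved nothing beyond the scatter. Among the measured compounds shown here, no measured compound carries a methoxy at that place, so the data offer no direct guide. The expectation for compound 4 in this assay is therefore no step beyond the scatter, a 1.0-fold lower number from compound 3 to compound 4 (0.01 log units; within the scatter). Compound 4 is estimated at 30000 nM, with a range from 12000 nM to 80000 nM.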

Compound 4, concentration for 50% growth inhibition: 19000 nM
Beside the measured number, compound 4's estimate is 1.6-fold (0.20 log units) above it; the range from low to high includes it.
By their numbers in this assay, from the lowest: compound 1; then compounds 4, 3 and 2 (each within the scatter of the next).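

In this assay, this aromatic carbon has now been seen with hydrogen, bromo and methoxy, and the step from bromo to methoxy, a 1.6-fold lower number from compound 3 to compound 4 (0.21 log units; within the scatter), is as small as the earlier bromo step when read against the scatter. The step from hydrogen to methoxy, a 1.8-fold lower number from compound 2 to compound 4 (0.27 log units; within the scatter), also stays within the scatter, so compound 2, compound 3 and compound 4 cannot be told apart here. Methoxy adds a hydrogen-bond acceptor and a second heavy atom at this place, yet neither addition comes with a step beyond the scatter. Nothing in the data explains this lack of separation.

From the compounds shown here alone, whether an amine, a carboxylic acid or a longer alkoxy chain on this carbon would give a step beyond the scatter remains open. So does the effect of methoxy on the other carbons of this aromatic ring.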